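The compounds below may be only part of what the source reports. "The series", "measured", "known", "first", "only" and "open" are said of these compounds alone.

Measured so far in a physicochemical assay for lipophilicity, in phosphate buffer, measured as octanol-water partition; a lower number here means a more polar compound, a higher number a more lipophilic compound:
compound 1, `Cc1ccccc1NC(=S)NC(=O)Nc1ccc2c(c1)C(=O)C(=O)N2Cc1ccccc1`, gives 2.98;
compound 2, `COc1cccc(NC(=S)NC(=O)Nc2ccc3c(c2)C(=O)C(=O)N3Cc2ccccc2)c1`, gives 2.4;
compound 3, `Cc1ccccc1NC(=S)NC(=O)Nc1ccc2c(c1)C(=O)C(=O)N2Cc1ccccc1Cl`, gives 3.7.

Among these three numbers compound 3 stands highest in this assay: the nearest to it is compound 1, which lies a number 0.72 log units higher from compound 1 to compound 3 (beyond the scatter) when read from compound 1 up to compound 3, and the furthest is compound 2.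

The next compound, compound 4, `COc1ccc(NC(=S)NC(=O)Nc2ccc3c(c2)C(=O)C(=O)N3Cc2ccccc2Cl)cc1`, has not yet been measured. It differs from compound 3 in one place: 4-methoxyphenyl in place of 2-methylphenyl on an amide-type nitrogen. Among the measured compounds shown here, one measured step bears on this change, the swap of the methylphenyl for a methoxyphenyl between compound 1 and compound 2, which gave a number 0.58 log units lower from compound 1 to compound 2 (beyond the scatter); there the methoxy group sat at a different position of the ring, so the comparison is only approximate. The chloro group that distinguishes compound 3 from compound 1 is kept in compound 4, so the step of a number 0.72 log units higher from compound 1 to compound 3 (beyond the scatter) does not enter here.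

Compound 4 is therefore expected to come out lower than compound 3 in this assay by about a number 0.60 log units lower from compound 3 to compound 4 (beyond the scatter). The estimate for compound 4 is 3.1, with a range from 2.7 to 3.5.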

Compound 4, partition coefficient: 3.24
Estimate against measurement, compound 4: 0.14 log units below, within the range that was stated.
By their numbers in this assay, from the lowest: compound 2; then compounds 1 and 4 (each within the scatter of the next); then compound 3.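

In this assay, putting 4-methoxyphenyl in place of 2-methylphenyl on the amide-type nitrogen gives a number 0.46 log units lower from compound 3 to compound 4 (beyond the scatter). The earlier compounds shown here showed a swap at this nitrogen only with 3-methoxyphenyl and without the chloro, as a number 0.58 log units lower from compound 1 to compound 2 (beyond the scatter); the new step shows a fall in the same direction with a different methoxyphenyl and with the chloro kept. Nothing measured here accounts for either step.

The two methoxyphenyl groups stand on different backgrounds, one with the chloro and one without, so the part played by the place of the methoxy cannot be told apart from that of the chloro. On these data alone, how a carboxylic acid or a dimethylamino group on this phenyl ring would read in this assay also remains open.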